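Cyclohexylmethyl for acetamidobenzyl at the piperidine amine

This account rests on a few compounds, and the source may have more. Where it says the series, first, only, none or still open, it means among the compounds named here.

Compound 1 `OC1(CNCc2ccccc2)CCN(CCCc2c[nH]c3ccc(-n4cnnc4)cc23)CC1`: 47 nM
Compound 2 `CC(=O)Nc1ccc(CNCC2(O)CCN(CCCc3c[nH]c4ccc(-n5cnnc5)cc34)CC2)cc1`: 30 nM

In an assay on CHO cells with 5-hydroxytryptamine receptor 1B (Homo sapiens) as the target (a lower number here means a stronger inhibitor, a higher number a weaker inhibitor), compound 2 gives the lower of the two numbers; its step to compound 1 is within the scatter, as a 1.6-fold lower number from compound 1 to compound 2 (0.19 log units; within the scatter) shows. Compound 3 `CN(CC1CCCCC1)CC1(O)CCN(CCCc2c[nH]c3ccc(-n4cnnc4)cc23)CC1` differs from compound 2 by (cyclohexylmethyl)(methyl)amino in place of (4-acetamidobenzyl)amino on a saturated chain carbon bound to a saturated ring carbon. Among the compounds with values here, only the step from compound 1 to compound 2 bears on this change, and only on the acetamido part, which it shows to matter little. The remaining change, a secondary benzylamine replaced by a tertiary amine on a saturated ring, has no measured parallel here. A modest weakening is expected, a 2.7-fold higher number from compound 2 to compound 3 (0.43 log units; beyond the scatter), so compound 3 is estimated at 80 nM, between 25 nM and 300 nM.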

Compound 3, half-maximal inhibitory concentration: 27 nM
The estimate for compound 3 lay 3.0-fold (0.47 log units) above the measured number; measured number inside the range.
By their numbers in this assay, from the lowest: compounds 3, 2 and 1 (each within the scatter of the next).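

In this assay, (cyclohexylmethyl)(methyl)amino on this saturated chain carbon reads like the groups with a benzyl, with a 1.1-fold lower number from compound 2 to compound 3 (0.05 log units; within the scatter) and a 1.7-fold lower number from compound 1 to compound 3 (0.24 log units; within the scatter). A number in this range therefore does not need the six-membered aromatic ring of carbon only or the hydrogen-bond donors that (4-acetamidobenzyl)amino brings. No measurement available here accounts for this result.

The compounds shown do not separate the contribution of the methyl from that of the cyclohexylmethyl. They also leave open how a carboxylic acid or a longer chain on this amine would read.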